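Sec-butyl for isobutyl on the amine nitrogen

The compounds below may be only part of what the source reports. "The series", "measured", "known", "first", "only" and "open" are said of these compounds alone.

Compound 1 `COc1cc(/C=C/C(=O)/C=C(/C=C/c2ccc(OC(C)=O)c(OC)c2)NC2CCCCC2)ccc1OC(C)=O` and compound 2 `COc1cc(/C=C/C(=O)/C=C(/C=C/c2ccc(OC(C)=O)c(OC)c2)NCC(C)C)ccc1OC(C)=O` share one core and differ only in the group on the amine nitrogen. In a functional assay on CHO-K1 cells (Cricetulus griseus) for inhibition, read by sulforhodamine B assay, with a stated time of 72 h (on this read-out lower numbers stand for stronger inhibition and higher numbers for weaker inhibition), compound 1 gives > 25000 nM, which is a limit of the assay and not a number. In this assay compound 2 gives > 25000 nM, likewise a limit and not a number. Among the measured compounds shown here, compound 2 therefore has no exact position, and the series so far sits together: the limit of > 25000 nM in this assay, at which 2 of the 2 values shown sit.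

Compound 3 `CCC(C)NC(=C\C(=O)/C=C/c1ccc(OC(C)=O)c(OC)c1)/C=C/c1ccc(OC(C)=O)c(OC)c1` has sec-butyl in place of isobutyl on an amine nitrogen, a rearrangement of the same atoms: sec-butyl in place of isobutyl on an amine nitrogen.

For the measured compounds named here, only one measured step bears on this change, a step that the two limits leave unreadable from compound 1 to compound 2, and it gives no usable size. Its replacement of cyclohexyl with isobutyl left both values at the limit, so no step beyond the scatter is expected in this assay, and no direction can be assigned. For compound 3 the expected value is 30000 nM, with an estimated range of 15000 nM to 60000 nM. The expected step is a step that the limit leaves unreadable from compound 2 to compound 3, and a report as a limit is the likeliest outcome.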

Compound 3, half-maximal inhibitory concentration: > 25000 nM
Compound 3 ended at the assay's limit; the forecaster's own chance of this, stated with the estimate: 85%; the middle value lies beyond the limit too.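

In this assay compound 3 gives > 25000 nM, a limit of the assay and not a number. No new step can be read between compound 3 and either compound 1 or compound 2, and the three compounds sit together: the limit of > 25000 nM in this assay, at which 3 of the 3 values shown sit.

The compounds shown leave open how any of these amine nitrogen groups would rank in this assay, as none has an exact value.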